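The compounds below may be only part of what the source reports. "The series", "measured", "known", "first", "only" and "open" are said of these compounds alone.

Measured compounds in an assay on RBL cells for inhibition of Polyunsaturated fatty acid 5-lipoxygenase (Rattus norvegicus); a higher number here means a weaker inhibitor, a lower number a stronger inhibitor:
compound 1 `CC(=O)N(O)C(C)c1ccc(OCCc2ccccc2)cc1`, 410 nM
compound 2 `CC(c1ccc2oc(-c3ccccc3)cc2c1)N(O)C(=O)c1ccco1`, 40 nM
compound 3 `COC(=O)CCCC(=O)N(O)C(C)c1ccc2oc(-c3cc(OC)c(OC)c(OC)c3)cc2c1`, 40 nM

Compound 2 stands level with compound 3 at the digits shown; the two together give the lowest numbers of the three, and the gap between them is within the scatter. Compound 1 is the furthest off, with a higher number beyond the scatter.

Compound 4 `CC(c1ccc2oc(-c3ccccc3)cc2c1)N(O)C(N)=O` has not yet been measured. It differs from compound 2 in a single place: amino in place of furan-2-yl on a carbonyl carbon; cut one bond further out, this reads (furan-2-yl)carbonyl to carbamoyl. Among the compounds with values here, no pair among the measured compounds shows this change, so nothing measured fixes its size or direction. The expectation is therefore a step of limited size in this assay, most likely within the scatter, with the direction left open. Compound 4 is estimated at 35 nM, in a range from 10 nM to 130 nM. This estimate means a step of a 1.1-fold lower number from compound 2 to compound 4 (0.06 log units; within the scatter), expected to fall inside the usual spread of repeated measurements.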

Compound 4, half-maximal inhibitory concentration: 410 nM
Compound 4: the middle estimate sits 12-fold (1.07 log units) below what was measured, and the stated range ends below it.
By their numbers in this assay, from the lowest: compounds 2 and 3 (each within the scatter of the next); then compounds 1 and 4 (each within the scatter of the next).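

The carbonyl substituent is not a silent position in this assay: amino in place of furan-2-yl on a carbonyl carbon gives a 10-fold higher number from compound 2 to compound 4 (1.01 log units; beyond the scatter) with the rest of the structure unchanged. Within the data shown here, the earlier compounds held no pair differing in one place, so this is the first direct reading of how far this series responds to a change at this position. Nothing available explains the size of the step.

Open, going by these compounds, is whether the step tracks the departure of the furan-2-yl ring or the arrival of the amino group; a thiophene-2-yl, a methylamino or a dimethylamino group on the same carbonyl carbon would help separate the two. Also open, on these data alone, is whether the same change keeps its size on the core of compound 3.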